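Ester chain length and cell growth inhibition

This account rests on a few compounds, and the source may have more. Where it says the series, first, only, none or still open, it means among the compounds named here.

Compound 1, `CCCCCCCCCC(=O)O[C@H]1[C@H](O)[C@H](n2ccc(N)nc2=O)O[C@@H]1CO`, gives 0.09 ug/mL in a functional assay on HeLa cells (Homo sapiens) for cytotoxicity, read by cell counting, with a stated time of 48 h; a higher number here means that more compound is needed for the effect, a lower number that less compound is needed.
Compound 2, `CC(=O)O[C@H]1[C@H](O)[C@H](n2ccc(N)nc2=O)O[C@@H]1CO`, gives 0.14 ug/mL.
Compound 3, `CCCCCCCCCCCC(=O)O[C@H]1[C@H](O)[C@H](n2ccc(N)nc2=O)O[C@@H]1CO`, gives 0.08 ug/mL.

Compound 3 has the lowest number of the three, but only just: the step of a 1.1-fold lower number from compound 1 to compound 3 (0.05 log units; within the scatter) and the step of a 1.8-fold lower number from compound 2 to compound 3 (0.24 log units; within the scatter) both lie within the scatter, so no ordering can be read from them. Compound 4, `CCCC(=O)O[C@H]1[C@H](O)[C@H](n2ccc(N)nc2=O)O[C@@H]1CO`, shortens the ester chain of compound 3: hydrogen in place of octyl on a saturated chain carbon, three bonds along the chain from a carbonyl carbon. Among the compounds with values here, the steps that bear on this change are a 1.6-fold higher number from compound 1 to compound 2 (0.19 log units; within the scatter) and a 1.8-fold lower number from compound 2 to compound 3 (0.24 log units; within the scatter), where a long chain was removed or added and the number barely moved. The expectation is therefore a step of a 1.4-fold higher number from compound 3 to compound 4 (0.14 log units; within the scatter), nothing beyond the scatter. Compound 4 is estimated at 0.11 ug/mL, with a range from 0.05 ug/mL to 0.25 ug/mL.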

Compound 4, concentration for half-maximal effect: 0.11 ug/mL
Compound 4: middle estimate and measured number agree at the digits printed; the measured number falls inside the stated range.
By their numbers in this assay, from the lowest: compounds 3, 1, 4 and 2 (each within the scatter of the next).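

Compound 4 adds a chain of intermediate length, and in this assay all of its steps lie within the scatter: a 1.4-fold higher number from compound 3 to compound 4 (0.14 log units; within the scatter), a 1.3-fold lower number from compound 2 to compound 4 (0.10 log units; within the scatter) and a 1.2-fold higher number from compound 1 to compound 4 (0.09 log units; within the scatter). Replacing octyl with hydrogen at this place behaves like the earlier shortening on another chain: the same change on two cores in this assay, a 1.6-fold higher number (0.19 log units; within the scatter) from compound 1 to compound 2 and a 1.4-fold higher number (0.14 log units; within the scatter) from compound 3 to compound 4, 1.1-fold (0.05 log units) apart, within the scatter of two such steps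
Adding ethyl on the saturated chain carbon bound to the carbonyl carbon also matches an earlier lengthening: the same change on two cores in this assay, a 1.1-fold lower number (0.05 log units; within the scatter) from compound 1 to compound 3 and a 1.3-fold lower number (0.10 log units; within the scatter) from compound 2 to compound 4, 1.1-fold (0.05 log units) apart, within the scatter of two such steps

From the compounds shown here alone, all four compounds carry a plain saturated chain, so the effect of an amine or a carboxylic acid at the chain end remains open. So does that of a longer chain than in compound 3.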